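This account rests on a few compounds, and the source may have more. Where it says the series, first, only, none or still open, it means among the compounds named here.

Compound 1 `Cc1ccc(-n2cc(C(=O)Nc3cc(F)cc(F)c3)c(=O)c3ccc(N(C)C)nc32)cc1OCCCCCCC[N+]12CCN(CC1)CC2`: 5.07%
Compound 2 `CN(C)c1ccc2c(=O)c(C(=O)Nc3cc(F)cc(F)c3)cn(-c3ccc(Cl)c(OCCCCCCC[N+]45CCN(CC4)CC5)c3)c2n1`: 8.08%
Compound 3 `Cc1ccc(-n2cc(C(=O)Nc3cc(F)cc(F)c3)c(=O)c3ccc(N(C)C)nc32)cc1OCCCCCCC[N+]1(C)CCN(C)CC1`: 10.4%

All three were tested in an assay on LX2 cells for inhibition of COL1A1 promoter (Homo sapiens), read by a luciferase reporter, with a stated time of 24 h, tested at 20 uM; on this read-out lower numbers stand for a weaker effect and higher numbers for a stronger effect at the one concentration tested. Compound 2 gives the second highest of the three numbers, but its gaps to compound 1 and to compound 3 both lie within the usual scatter, so the three cannot be told apart. Compound 4 `CC[N+]1(CCCCCCCOc2cc(-n3cc(C(=O)Nc4cc(F)cc(F)c4)c(=O)c4ccc(N(C)C)nc43)ccc2Cl)CCCC1` is not yet measured; it differs from compound 2 by a group of 7 heavy atoms (6 carbon, 1 nitrogen; one five-membered non-aromatic ring with 1 hetero atom) in place of a group of 8 heavy atoms (6 carbon, 2 nitrogen; 2 six-membered non-aromatic rings with 2 hetero atoms each), on a saturated chain carbon, seven bonds along the chain from an oxygen on an aromatic ring. The step that bears on this change is a number 5.3 percentage points higher from compound 1 to compound 3 (within the scatter), a swap at the same place on the chain, which stayed within the scatter. The step of a number 3 percentage points higher from compound 1 to compound 2 (within the scatter) concerns another place and was also within scatter. Compound 4 is therefore expected to show a number 0.1 percentage points lower from compound 2 to compound 4 (within the scatter), with no move beyond the scatter. The estimate for compound 4 is 8%, between -4% and 20%.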

Compound 4, a percentage reported as inhibition, at one concentration (the size of the read-out at that concentration, not a potency): 46%
Estimate against measurement, compound 4: 38 percentage points below; measured number above the stated range.
By their numbers in this assay, from the lowest: compounds 1, 2 and 3 (each within the scatter of the next); then compound 4.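

In this assay, the end group on this chain can change the read-out: the swap gives a number 37.9 percentage points higher from compound 2 to compound 4 (beyond the scatter), whereas the earlier swap at this place gave a number 5.3 percentage points higher from compound 1 to compound 3 (within the scatter). So this position is not indifferent to what sits there, even though both groups in the new step carry a net charge of +1. Nothing measured here explains the rise.

A piperidine ring at this place would help show whether ring size matters. On these data alone, whether the gain survives with methyl in place of chloro on the aromatic ring remains open.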